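The compounds below may be only part of what the source reports. "The series", "measured", "known", "first", "only" and "open" are said of these compounds alone.

Three compounds have been measured in an assay on isolated protein for inhibition of glutathione S-transferase Mu 2 (Homo sapiens), with a stated time of 10 min; on this read-out higher numbers stand for weaker inhibition and lower numbers for stronger inhibition:

compound 1 `O=C(CCC(=O)OCCCCCCSc1ccc([N+](=O)[O-])c2nonc12)Nc1ccccc1F`, 350 nM
compound 2 `Cc1ccc(NC(=O)CCC(=O)OCCCCCCSc2ccc([N+](=O)[O-])c3nonc23)cc1`, 390 nM
compound 3 `CCN(CC)CCCNC(=O)CCC(=O)OCCCCCCSc1ccc([N+](=O)[O-])c2nonc12`, 440 nM

All three share the same core and differ only in the group carried on the amide-type nitrogen. Compound 3 holds the highest of the three numbers, but its gaps to the others are small: a 1.1-fold higher number from compound 2 to compound 3 (0.05 log units; within the scatter) and a 1.3-fold higher number from compound 1 to compound 3 (0.10 log units; within the scatter) are both within the usual scatter, so the three compounds cannot be told apart on these data.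

Compound 4 `O=C(CCC(=O)N1CCOCC1)OCCCCCCSc1ccc([N+](=O)[O-])c2nonc12` is the next step from compound 3. The change is morpholin-4-yl in place of (3-(diethylamino)propyl)amino on a carbonyl carbon. For the measured compounds named here, every measured step so far bears on this position, since each swaps the group attached to that same amide: a 1.1-fold higher number from compound 1 to compound 2 (0.05 log units; within the scatter), a 1.3-fold higher number from compound 1 to compound 3 (0.10 log units; within the scatter) and a 1.1-fold higher number from compound 2 to compound 3 (0.05 log units; within the scatter). None of them moved the number beyond the scatter, whether the group was an aromatic ring or a flexible chain carrying an amine. Going by the values given here, no measured step has yet removed the amide hydrogen or placed a ring directly on the carbonyl carbon, so the expectation rests on those three steps alone. The expected outcome is a step of no real size, a 1.0-fold higher number from compound 3 to compound 4 (0.01 log units; within the scatter), in this assay. Compound 4 is therefore estimated at 450 nM, with a likely range from 200 nM to 1000 nM.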

Compound 4, half-maximal inhibitory concentration: 170 nM
Compound 4: middle estimate off by 2.6-fold (0.42 log units), on the high side; measured number outside the range, below it.
By their numbers in this assay, from the lowest: compound 4; then compounds 1, 2 and 3 (each within the scatter of the next).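

In this assay this position proves sensitive to the group on the carbonyl carbon after all: morpholin-4-yl gives a 2.6-fold lower number from compound 3 to compound 4 (0.41 log units; beyond the scatter) and a 2.3-fold lower number from compound 2 to compound 4 (0.36 log units; beyond the scatter) and also a 2.1-fold lower number from compound 1 to compound 4 (0.31 log units; beyond the scatter) as modest steps beyond the scatter, whereas the swaps among the three earlier groups all stayed within it. For the compounds shown here, compound 4 is also the only compound here without the amide hydrogen and the only one with a six-membered non-aromatic ring attached through its nitrogen to the carbonyl carbon, so these two differences arrive together and cannot be separated on these data. No measurement shown here explains why the number falls with this change.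

The compounds shown leave open whether the lower number follows the loss of the amide hydrogen, the ring, or the ring oxygen of morpholin-4-yl. Piperidin-1-yl would keep the ring without that oxygen and dimethylamino would lack the amide hydrogen without any ring, so each would test one of these differences on the same shared core.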